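Fluoro in place of methyl: what compound 4 should give

A few compounds are considered here, and "the series" means these few. Any claim that something is new, unique, unknown or untested is made for them only; others in the source may bear on it.

Compound 1 `Cc1ccc(-c2nc(CNc3ccc(C(=O)NO)cc3)n(-c3ccccc3)n2)cc1` was measured in an assay on Sf9 cells for inhibition of protein deacetylase HDAC6 (Homo sapiens), read by fluorescence, with a stated time of 40 min, tested at 100 nM (a lower number here means less inhibition, a higher number more inhibition at the concentration tested (going by the name of the read-out)), where compound 1 gives 62.2%. Compound 2 `O=C(NO)c1ccc(NCc2nc(-c3cccnc3)nn2-c2ccccc2)cc1` gives 57.7% and compound 3 `O=C(NO)c1ccc(NCc2nc(-c3cccc(Cl)c3)nn2-c2ccccc2)cc1` gives 61.2%, so the number for compound 1 is the largest of the three, yet a number 4.5 percentage points lower from compound 1 to compound 2 (within the scatter) and a number 1 percentage points lower from compound 1 to compound 3 (within the scatter) both stay within the scatter, as does a number 3.5 percentage points higher from compound 2 to compound 3 (within the scatter). Compound 4 `O=C(NO)c1ccc(NCc2nc(-c3ccc(F)cc3)nn2-c2ccccc2)cc1` differs from compound 1 by fluoro in place of methyl on an aromatic carbon. The two steps that bear on this, exchanging the 4-methylphenyl for pyridin-3-yl and for 3-chlorophenyl, left the read-out essentially unchanged, so a step of no size beyond the scatter is expected here: a number 2.2 percentage points lower from compound 1 to compound 4 (within the scatter). Compound 4 is therefore expected to give 60%, with a range from 48% to 72%.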

Compound 4, a percentage reported as inhibition, at one concentration (the size of the read-out at that concentration, not a potency): 70.9%
Compound 4: the middle estimate sits 10.9 percentage points below what was measured; the range from low to high includes it.
By their numbers in this assay, from the lowest: compounds 2, 3, 1 and 4 (each within the scatter of the next, the first and the last beyond it).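

In this assay (this assay), the position now gives its first step beyond the scatter (a number 13.2 percentage points higher from compound 2 to compound 4 (beyond the scatter)), with 4-fluorophenyl in place of pyridin-3-yl. The other two steps (a number 8.7 percentage points higher from compound 1 to compound 4 (within the scatter)) and (a number 9.7 percentage points higher from compound 3 to compound 4 (within the scatter)) remain within the scatter, so 4-fluorophenyl cannot be told apart from 4-methylphenyl or 3-chlorophenyl. Nothing available accounts for the step from pyridin-3-yl. As far as these compounds go, what an amine or a carboxylic acid in place of the fluoro would give remains open, as does whether any other group at this position would stand beyond the scatter from compound 4.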